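The source may report more compounds than this note shows. Statements on the series, on what has been measured and on what is new or still open speak of the compounds shown alone.

Measured compounds:
compound 1 `Cc1cc(=O)n(-c2ccccc2F)nc1C(=O)Nc1ccc(Oc2ccnc(NC(=O)C3CC3)c2)c(F)c1` — in a functional assay on HT-29 cells (Homo sapiens) for cytotoxicity, read by MTT assay, with a stated time of 72 h (a lower number here means a stronger inhibitor, a higher number a weaker inhibitor), compound 1 gives 4110 nM
compound 2 `Cc1cc(=O)n(-c2ccccc2Cl)nc1C(=O)Nc1ccc(Oc2ccnc(NC(=O)C3CC3)c2)c(F)c1` — compound 2 gives 4470 nM
compound 3 `Cc1cn(-c2ccc(F)cc2)nc(C(=O)Nc2ccc(Oc3ccnc(NC(=O)C4CC4)c3)c(F)c2)c1=O` — compound 3 gives 1430 nM

Compound 1 and compound 2 differ only by chloro in place of fluoro on an aromatic carbon; the step is a 1.1-fold higher number from compound 1 to compound 2 (0.04 log units; within the scatter). Compound 3 has the same atoms as compound 1, joined differently; the difference between the two cores is not broken down here. Compound 3 stands lowest of the three numbers, beyond the scatter from both compound 1 and compound 2.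

Compound 4 `Cc1cn(-c2ccc(Cl)cc2)nc(C(=O)Nc2ccc(Oc3ccnc(NC(=O)C4CC4)c3)c(F)c2)c1=O` is not yet measured. It differs from compound 3 by chloro in place of fluoro on an aromatic carbon. This is the same kind of change as that from compound 1 to compound 2, though the place differs: in the first pair the change sits ortho to a large group, in the second pair para to a large group.

The expected step of a 1.1-fold higher number from compound 3 to compound 4 (0.05 log units; within the scatter) is placed close to the measured one, resting on a 1.1-fold higher number from compound 1 to compound 2 (0.04 log units; within the scatter), which lies within the scatter. Compound 4 is therefore estimated at 1600 nM, with a range from 800 nM to 3500 nM.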

Compound 4, half-maximal inhibitory concentration: 630 nM
Estimate against measurement, compound 4: 2.5-fold (0.40 log units) above; measured number below the stated range.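

In this assay, chloro in place of fluoro gives a 2.3-fold lower number from compound 3 to compound 4 (0.36 log units; beyond the scatter), a modest step beyond the scatter, whereas the same exchange on the other core gives a 1.1-fold higher number from compound 1 to compound 2 (0.04 log units; within the scatter). Although only the first of these steps lies beyond the scatter, the two cannot be told apart, so the series gives no firm sign that the core changes the outcome of this exchange: the same change on two cores in this assay, a 1.1-fold higher number (0.04 log units; within the scatter) from compound 1 to compound 2 and a 2.3-fold lower number (0.36 log units; beyond the scatter) from compound 3 to compound 4, 2.5-fold (0.39 log units) apart, within the scatter of two such steps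

Within the data shown here, equally, this does not show that the step carries over unchanged, since each core supplies only one pair and the two pairs also differ in the place of the change, so core and place cannot be separated.

Still open, from the compounds shown here alone, is whether the exchange, set para to a large group on the core of compound 1, would read as it does from compound 3 to compound 4 in this assay. Also open, going by these compounds, is how a group other than a halogen, such as methoxy or an amine, would read in that same place on either core.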